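The compounds below may be only part of what the source reports. "The series", "measured", "known", "first", "only" and "open" are said of these compounds alone.

Measured so far:
compound 1, `Cc1cc(NC(=O)Nc2ccc(O)cc2)c2ccccc2n1`, which in an ADME assay on HEK293 cells (Homo sapiens) for cytotoxicity, with a stated time of 72 h (a lower number here means that less compound is needed, a higher number that more compound is needed for the effect), reaches only the limit > 25000 nM.
compound 2, `COC(=O)c1cccc(NC(=O)Nc2cc(C)nc3ccccc23)c1`, which in this assay gives 26000 nM.

Within the data shown here, compound 2 holds the only actual number in this set; the other value is a limit, not a number. The limit reached by compound 1 is the point at which one of the two values sits (the limit of > 25000 nM in this assay, at which 1 of the 2 values shown sits). Among the measured compounds shown here, both compounds therefore sit at the high-concentration end of what this assay reports, and no step between measured compounds is available to judge how a single change moves the read-out.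

Compound 3, `Cc1cc(NC(=O)Nc2cccc(Cl)c2)c2ccccc2n1`, has not yet been measured in this assay. Relative to compound 2 it differs in one place (chloro in place of methoxycarbonyl on an aromatic carbon). For the measured compounds named here, with no measured step to draw on, no change beyond the usual scatter is expected in either direction. For compound 3 the estimate is 26000 nM (range 10000 nM to 70000 nM), which corresponds to an expected step of no change at the digits printed from compound 2 to compound 3 (within the scatter). There is a fair chance that this assay returns a limit rather than a number for compound 3.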

Compound 3, half-maximal effective concentration: 21000 nM
Beside the measured number, compound 3's estimate is 1.2-fold (0.09 log units) above it; low and high end bracket the measured number.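

In this assay, the compounds now give a second actual number, and it shows that on this aromatic carbon, meta to a large group, replacing methoxycarbonyl (4 heavy atoms, 2 hydrogen-bond acceptors) with chloro (1 heavy atom, no hydrogen-bond acceptors) leaves the read-out within the scatter: a 1.2-fold lower number from compound 2 to compound 3 (0.09 log units; within the scatter). A change of the whole aryl group, 3-chlorophenyl in place of 4-hydroxyphenyl on an amide-type nitrogen, gives an at least 1.1-fold lower number from compound 1 to compound 3 (0.07 log units; that floor lies within the scatter), and that floor shows no real difference. Compound 1 remains a limit and not a number, so the full size of that step cannot be read: the limit of > 25000 nM in this assay, at which 1 of the 3 values shown sits.

Whether any group on this aromatic carbon can move the read-out beyond the scatter stays open, since no step shown does so and neither an amine nor a carboxylic acid at this place is among the compounds shown. On these data alone, the methyl group and the rest of the shared core are the same in all three compounds, so the effect of a change there, for example a longer chain in place of the methyl group, also remains open.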